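The source may hold more compounds than are shown below. What is called first, only, known or untested is meant among the compounds shown, and "the series" means these compounds.

The measured compounds:
compound 1, `C=CCN1[C@H](c2ccc([N+](=O)[O-])cc2)C(C(=O)OCC)C(=O)C(C(=O)OCC)[C@@H]1c1ccc([N+](=O)[O-])cc1`: > 100 uM
compound 2, `COC(=O)C1C(=O)C(C(=O)OC)[C@H](c2cccc([N+](=O)[O-])c2)N(Cc2ccccc2)[C@@H]1c1cccc([N+](=O)[O-])c1`: > 100 uM
compound 3, `COC(=O)C1C(=O)C(C(=O)OC)[C@H](c2ccccn2)N(CCCC(=O)O)[C@@H]1c1ccccn1`: 46 uM

In an ADME assay on J774.1 cells (Mus musculus) for cytotoxicity, with a stated time of 48 h (a higher number here means that more compound is needed for the effect, a lower number that less compound is needed), compound 1 reaches only the limit of the assay, > 100 uM, and not a number. The same holds for compound 2, which in this assay gives > 100 uM, again a limit. Going by the values given here, compound 3 is therefore the only compound of the three with an actual number in this assay, and there it gives 46 uM. Among the compounds with values here, two of the three values sit at the limit of > 100 uM in this assay, at which 2 of the 3 values shown sit, so compound 3 stands as the one compound whose effect is seen within the tested range.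

Compound 4, `COC(=O)C1C(=O)C(C(=O)OC)[C@H](c2ccccn2)N(Cc2ccccc2)[C@@H]1c1ccccn1`, is not yet measured in this assay. It differs from compound 3 in one place: phenyl in place of 2-carboxyethyl on a saturated chain carbon bound to an amine nitrogen in a ring, which, read one bond further out, is 3-carboxypropyl giving way to benzyl. No measured pair shows this exact exchange, and no cause can be attached to it from what is shown. Within the data shown here, compound 2 also carries benzyl on the ring nitrogen and gives only a limit, but it shares no measured step with compound 4, so this serves as a hint and nothing more.

Compound 4 is estimated in this assay at 80 uM, within a range from 30 uM to 200 uM. The expected step from compound 3 to compound 4, a 1.7-fold higher number from compound 3 to compound 4 (0.24 log units; within the scatter), is a modest rise that may not exceed the scatter, with a real chance that only a limit is reported.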

Compound 4, concentration for half-maximal effect: 34 uM
Compound 4: the middle estimate sits 2.4-fold (0.37 log units) above what was measured, within the range that was stated.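

In this assay, the exchange of 3-carboxypropyl for benzyl on the amine nitrogen in the ring gives a 1.4-fold lower number from compound 3 to compound 4 (0.13 log units; within the scatter), so the two compounds cannot be told apart. This is the first change at this position that can be read on its own, and it shows that on this shared core a chain ending in a carboxylic acid and a benzyl group carrying no acid both give an actual number, with nothing shown to explain why they match. Compound 4 thus joins compound 3 as a second compound with a number, while the other two compounds stay at the limit of the assay: the limit of > 100 uM in this assay, at which 2 of the 4 values shown sit.

As far as these compounds go, compounds 1 and 2 differ from these two in more than one place, so it stays open which of their differences separates a limit from a number, and whether the exchange would read the same on their cores. Also open, from the compounds shown here alone, is whether an amine at the end of the chain, a longer chain ending in a carboxylic acid, or a methoxy group on the benzyl ring would keep the number in this region.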